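Chain-terminus variation on the butyrolactone core: formyl analogue

The compounds below may be only part of what the source reports. "The series", "measured", "known", "first", "only" and "open" are said of these compounds alone.

Measured compounds in a functional assay on CCRF-CEM cells (Homo sapiens) for antiproliferative activity; on this read-out higher numbers stand for weaker inhibition of growth and lower numbers for stronger inhibition of growth:
- compound 1 `CCCCCOCCCCCCC/C=C1\CC(CO)(COC(=O)C(C)(C)C)OC1=O`: 0.877 ug/mL
- compound 2 `COCCCCCCCCCCC/C=C1\CC(CO)(COC(=O)C(C)(C)C)OC1=O`: 0.701 ug/mL
- compound 3 `CC(=O)NCCCCCCCCCCCCCCC/C=C1\CC(CO)(COC(=O)C(C)(C)C)OC1=O`: 1.08 ug/mL

All three share the core of compound 1 and differ only at the far end of the side chain. The steps among them, a 1.3-fold lower number from compound 1 to compound 2 (0.10 log units; within the scatter), a 1.2-fold higher number from compound 1 to compound 3 (0.09 log units; within the scatter) and a 1.5-fold higher number from compound 2 to compound 3 (0.19 log units; within the scatter), all fall within the scatter of this assay. Compound 3 gives the highest of the three numbers, yet its steps to compound 1 and compound 2 are within the scatter, so no separation among the three can be claimed.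

Compound 4 `CC(C)(C)C(=O)OCC1(CO)C/C(=C\CCCCCCCCCCCCCCC=O)C(=O)O1` has not been measured. Relative to compound 3 the difference is formyl in place of acetamidomethyl on a saturated chain carbon, ten or more bonds along the chain from a double-bonded chain carbon.

Within the data shown here, the steps that bear on this change are the three terminal-group steps already seen, none of which moved the read-out beyond the scatter. On that basis a step from compound 3 to compound 4 of a 1.1-fold lower number from compound 3 to compound 4 (0.03 log units; within the scatter) is expected, with no direction that can be trusted. Compound 4 is therefore estimated at 1 ug/mL in this assay, with a range from 0.45 ug/mL to 2.2 ug/mL, pending the measurement.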

Compound 4, concentration for 50% growth inhibition: 0.933 ug/mL
For compound 4 the middle estimate is 1.1-fold (0.03 log units) above the measured one; the measured number falls inside the stated range.
By their numbers in this assay, from the lowest: compounds 2, 1, 4 and 3 (each within the scatter of the next).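

In this assay, formyl in place of acetamidomethyl on a saturated chain carbon, ten or more bonds along the chain from a double-bonded chain carbon, removes the nitrogen and the hydrogen-bond donor from the chain end, yet the result is only a 1.2-fold lower number from compound 3 to compound 4 (0.06 log units; within the scatter). Set against the other two chain ends, 3-formylpropyl in place of methoxy gives a 1.3-fold higher number from compound 2 to compound 4 (0.12 log units; within the scatter) and 7-formylheptyl in place of pentyloxy gives a 1.1-fold higher number from compound 1 to compound 4 (0.03 log units; within the scatter), so among these four compounds a formyl end cannot be separated from the methoxy, pentyloxy or acetamido ends, and no listed compound goes against this. No supporting data bear on why the read-out stays this flat across the terminal groups.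

On these data alone, it remains open whether an amine or a carboxylic acid at the chain end, or a markedly shorter or longer chain, would move the read-out beyond the scatter. Also open, as far as these compounds go, is whether the same flat response would hold with a change to the shared core of compound 1 rather than to the chain end.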